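Returning the Aryl Carbonyl: From Compound 3 to Compound 4

A few compounds are considered here, and "the series" means these few. Any claim that something is new, unique, unknown or untested is made for them only; others in the source may bear on it.

Three compounds have been measured in an assay on membranes from striatum (strain Sprague-Dawley) for displacement of a labelled ligand from sodium-dependent dopamine transporter (Rattus norvegicus), read by scintillation counting, with a stated time of 120 min; a lower number here means a stronger inhibitor, a higher number a weaker inhibitor:
- compound 1, `O=C(c1ccccc1)N1CCC(NCCSC(c2ccc(F)cc2)c2ccc(F)cc2)CC1`, gives 4.51 nM
- compound 2, `O=C(c1cc2ccccc2[nH]1)N1CCC(NCCSC(c2ccc(F)cc2)c2ccc(F)cc2)CC1`, gives 177 nM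
- compound 3, `Fc1ccc(C(SCCNC2CCN(Cc3cc4ccccc4o3)CC2)c2ccc(F)cc2)cc1`, gives 120 nM

Compound 3 stands second highest of the three: its value and that of compound 2 are within the scatter of each other, while compound 1 sits far lower, as the step of a 27-fold higher number from compound 1 to compound 3 (1.43 log units; beyond the scatter) shows. Compound 4, `O=C(c1ccc(F)cc1F)N1CCC(NCCSC(c2ccc(F)cc2)c2ccc(F)cc2)CC1`, carries the change ((2,4-difluorophenyl)carbonyl in place of (1-benzofuran-2-yl)methyl on an amine nitrogen in a ring).

This change runs opposite to the earlier loss. Replacing a benzoyl with a benzofuranylmethyl cost a 27-fold higher number from compound 1 to compound 3 (1.43 log units; beyond the scatter), and swapping benzoyl for an indolylcarbonyl cost a 39-fold higher number from compound 1 to compound 2 (1.59 log units; beyond the scatter), whereas the two weaker groups differ only by a 1.5-fold lower number from compound 2 to compound 3 (0.17 log units; within the scatter). Compound 4 restores an aryl carbonyl on the ring nitrogen, now bearing two fluorines, so a large drop in this assay is expected, roughly a 20-fold lower number from compound 3 to compound 4 (1.30 log units; beyond the scatter). Compound 4 is therefore estimated at 6 nM, with a range from 2 nM to 20 nM.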

Compound 4, inhibition constant: 30 nM
Compound 4: the middle estimate sits 5.0-fold (0.70 log units) below what was measured, and the stated range ends below it.
By their numbers in this assay, from the lowest: compound 1; then compound 4; then compounds 3 and 2 (each within the scatter of the next).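

In this assay, putting a carbonyl back on the ring nitrogen recovers only part of the lost binding, with a 4.0-fold lower number from compound 3 to compound 4 (0.60 log units; beyond the scatter). The group on that carbonyl also matters: a 5.9-fold lower number from compound 2 to compound 4 (0.77 log units; beyond the scatter) favours 2,4-difluorophenyl over 1H-indol-2-yl, yet a 6.7-fold higher number from compound 1 to compound 4 (0.82 log units; beyond the scatter) shows that adding the two fluorines to the phenyl ring leaves the carbonyl compound well short of compound 1. Nothing measured here explains why these groups rank in this order.

A phenyl carrying a single fluorine on the carbonyl carbon would show whether one fluorine is enough to produce this loss or both are needed. A plain benzyl on the ring nitrogen would separate the effect of the carbonyl from that of the aromatic ring.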